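Swapping a Cyclopentenyl Group for a Butyl Chain

The source may report more compounds than this note shows. Statements on the series, on what has been measured and on what is new or still open speak of the compounds shown alone.

Of the compounds shown here, two have been measured in a functional assay on HEK293 cells for agonist activity at Free fatty acid receptor 1 (Rattus norvegicus), read by fluorescence and calcium flux, with a stated time of 1 h; a higher number here means that more compound is needed for the effect, a lower number that less compound is needed. Compound 1 `COc1ccc(F)c(-c2cnc(COc3cccc([C@@H](CC(=O)O)C4CC4)c3)cc2C2=CCCC2(C)C)c1` gives 46 nM there, while compound 2 `COc1ccc(F)c(-c2ncc(COc3cccc([C@@H](CC(=O)O)C4CC4)c3)nc2C2=CCCC2(C)C)c1` gives 201 nM in this assay. Among these two values compound 2 stands highest, its nearest neighbour being compound 1 at a lower number, a gap beyond the scatter. Compound 3 `CCCCc1nc(COc2cccc([C@@H](CC(=O)O)C3CC3)c2)cnc1-c1cc(OC)ccc1F` has not yet been measured; it differs from compound 2 in one place, (butyl in place of 5,5-dimethylcyclopent-1-en-1-yl on an aromatic carbon), a butyl in place of 5,5-dimethylcyclopent-1-en-1-yl on an aromatic carbon. Among the compounds with values here, no pair of measured compounds shows this particular change, so the size of the step is uncertain. A modest move to a higher number is expected, a 1.6-fold higher number from compound 2 to compound 3 (0.20 log units; within the scatter), though one that could well fall within the scatter. Compound 3 is therefore estimated at 320 nM in this assay, with a range from 100 nM to 1000 nM.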

Compound 3, half-maximal effective concentration: 28 nM
For compound 3 the middle estimate is 11-fold (1.06 log units) above the measured one, and the stated range ends above it.
By their numbers in this assay, from the lowest: compounds 3 and 1 (each within the scatter of the next); then compound 2.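

In this assay, butyl in place of 5,5-dimethylcyclopent-1-en-1-yl gives a 7.2-fold lower number from compound 2 to compound 3 (0.86 log units; beyond the scatter), a step beyond the scatter. At this aromatic carbon, next to the ring nitrogen and ortho to a 2-fluoro-5-methoxyphenyl group, a low number therefore does not depend on the five-membered ring or its double bond, and a butyl chain with no ring serves at least as well in this pair. Nothing available here accounts for the size of the step. On these data alone, whether a propyl, pentyl or isobutyl group at this position would give a lower or a higher number than butyl remains open. So does whether the same swap on the core of compound 1 would bring a step of similar size.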